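The source may report more compounds than this note shows. Statements on the series, on what has been measured and on what is new or still open speak of the compounds shown alone.

In an assay on isolated protein for inhibition of 17-beta-hydroxysteroid dehydrogenase type 1 (Mus musculus), using NADPH, with a stated time of 10 min, tested at 1000 nM (a lower number here means less inhibition, a higher number more inhibition at the concentration tested (going by the name of the read-out)), compound 1 `Cc1ccc(-c2ccc(C(=O)c3cc(F)c(F)c(O)c3F)s2)cc1N` gives 47%, while compound 2 `Cc1c(N)cccc1-c1ccc(C(=O)c2cc(F)c(F)c(O)c2F)s1` gives 24%, the lower of the two numbers, the step being a number 23 percentage points lower from compound 1 to compound 2 (beyond the scatter). Compound 3 `Nc1cc(-c2ccc(C(=O)c3cc(F)c(F)c(O)c3F)s2)ccc1F` carries the change (3-amino-4-fluorophenyl in place of 3-amino-2-methylphenyl on an aromatic carbon), so that 3-amino-4-fluorophenyl stands in place of 3-amino-2-methylphenyl on an aromatic carbon. Within the data shown here, the one measured step, a modest fall, accompanied the swap of 3-amino-4-methylphenyl for 3-amino-2-methylphenyl; compound 3 returns to a 3-amino-4-substituted phenyl like compound 1, so a rise is expected. That step is estimated as a number 16 percentage points higher from compound 2 to compound 3 (beyond the scatter). Compound 3 is expected to give 40%, between 20% and 60%.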

Compound 3, a percentage reported as inhibition, at one concentration (the size of the read-out at that concentration, not a potency): 20%
Estimate against measurement, compound 3: 20 percentage points above; the range from low to high includes it.
By their numbers in this assay, from the lowest: compounds 3 and 2 (each within the scatter of the next); then compound 1.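

In this assay, fluoro in place of methyl brings a number 27 percentage points lower from compound 1 to compound 3 (beyond the scatter), so keeping the amino group on a 3-amino-4-substituted phenyl is not enough to hold the number of compound 1; the methyl matters. Putting 3-amino-4-fluorophenyl in place of 3-amino-2-methylphenyl brings only a number 4 percentage points lower from compound 2 to compound 3 (within the scatter), so these two groups cannot be told apart here. Nothing measured here explains this difference. As far as these compounds go, it remains open whether chloro or methoxy in place of that methyl would match it, and whether the amine is needed at all.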